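The compounds below may be only part of what the source reports. "The series", "measured", "known", "first", "only" and "open" are said of these compounds alone.

Measured so far in an ADME assay on WI-38 cells (Homo sapiens) for cytotoxicity, read by MTT assay, with a stated time of 72 h; on this read-out lower numbers stand for stronger inhibition and higher numbers for weaker inhibition:
- compound 1 `CC(C)(C)OC(=O)Nc1ccc(NC(=O)CCc2cccc3c2B(O)OC3)cc1`, a limit only: > 100000 nM
- compound 2 `O=C(CCc1cccc2c1B(O)OC2)Nc1cccc(-c2ccc(F)cc2)c1`: 4100 nM
- compound 3 `O=C(CCc1cccc2c1B(O)OC2)Nc1cccc(-c2cccc(OC(F)(F)F)c2)c1`: 9800 nM

Compound 1 returns only a limit of this assay, not a number, sitting at the limit of > 100000 nM in this assay, at which 1 of the 3 values shown sits. Among the two numbers recorded, compound 2 stands lowest; compound 3 is the nearest, with a number beyond the usual scatter above it. Within the data shown here, no pair of measured compounds differs in only one place, so no measured step can be read from these three.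

Compound 4 `O=C(CCc1cccc2c1B(O)OC2)Nc1cccc(-c2ccc(C(F)(F)F)cc2)c1` is not yet measured in this assay. Set against compound 2, the change is trifluoromethyl in place of fluoro on an aromatic carbon, read one bond further out as 4-fluorophenyl to 4-(trifluoromethyl)phenyl. The remainder of the structure, from the shared core through the amide to the biphenyl part, is unchanged. With no measured step of this kind in the series, the expectation for the step from compound 2 to compound 4 is of a small shift, if any, most likely within the scatter of this assay, leaning if at all toward a higher number, as seen for compound 3 carrying a larger fluorinated group. Compound 4 is therefore expected to give about 5500 nM, within 2000 nM to 16000 nM, the expected step being a 1.3-fold higher number from compound 2 to compound 4 (0.13 log units; within the scatter).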

Compound 4, half-maximal inhibitory concentration: 26000 nM
Compound 4: middle estimate off by 4.7-fold (0.67 log units), on the low side, outside the stated range (above it).
By their numbers in this assay, from the lowest: compound 2; then compound 3; then compound 4. At a limit, above all of these: compound 1.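

Working from this assay, this position proves sensitive to the group it carries: trifluoromethyl in place of fluoro on an aromatic carbon, para to a large group, gives a 6.3-fold higher number from compound 2 to compound 4 (0.80 log units; beyond the scatter) and so provides the first step in the series that can be read from a single change. The number moves toward weaker inhibition while the rest of the structure stays unchanged, so fluoro and trifluoromethyl are not interchangeable here in this cytotoxicity read-out. Nothing shown gives a cause for this step.

A single pair cannot show whether the trend extends to other groups at this place, such as an amine, a carboxylic acid or a nitrile. It also leaves open how an unsubstituted phenyl would stand against both compound 2 and compound 4.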